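From Ethyl to Isopropyl: a Limit Expected Once More

The source may hold more compounds than are shown below. What is called first, only, known or untested is meant among the compounds shown, and "the series" means these compounds.

compound 1 `Cc1cn([C@@H]2O[C@@H]3COP(=O)(O)O[C@H]3[C@H]2O)c(=O)nc1N` — > 200 ug/mL
compound 2 `CCc1cn([C@@H]2O[C@@H]3COP(=O)(O)O[C@H]3[C@H]2O)c(=O)nc1N` — > 200 ug/mL

Compound 1 `Cc1cn([C@@H]2O[C@@H]3COP(=O)(O)O[C@H]3[C@H]2O)c(=O)nc1N` reaches in a functional assay on L1210 cells (Mus musculus) for cytotoxicity (on this read-out higher numbers stand for weaker inhibition and lower numbers for stronger inhibition), only a limit of the assay, > 200 ug/mL. Compound 2 `CCc1cn([C@@H]2O[C@@H]3COP(=O)(O)O[C@H]3[C@H]2O)c(=O)nc1N` likewise shows in this assay only a limit, > 200 ug/mL. The step that the two limits leave unreadable from compound 1 to compound 2 therefore cannot be read, and compound 2 stands, with both values shown, at the limit of > 200 ug/mL in this assay, at which 2 of the 2 values shown sit.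

Compound 3 `CC(C)c1cn([C@@H]2O[C@@H]3COP(=O)(O)O[C@H]3[C@H]2O)c(=O)nc1N` differs from compound 2 by methyl in place of hydrogen on a saturated chain carbon bound to an aromatic carbon and a saturated chain carbon. Going by the values given here, the only measured step that bears on this change is a step that the two limits leave unreadable from compound 1 to compound 2, and it is unreadable, so no size of step in this assay can be inferred in either direction; the expectation is that compound 3 again sits at the limit.

Compound 3 is therefore estimated at 250 ug/mL in this assay, within 100 ug/mL to 1000 ug/mL. The expected step is a step that the limit leaves unreadable from compound 2 to compound 3, most likely reported only as a limit.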

Compound 3, concentration for 50% inhibition: > 200 ug/mL
Compound 3: a limit, no number; the forecaster's own chance of this, stated with the estimate: 85%; the middle value is on the limit's open side.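

Compound 1, compound 2 and compound 3 give only limits in this assay, so no step among them can be read: the limit of > 200 ug/mL in this assay, at which 3 of the 3 values shown sit.

The compounds shown leave open whether methyl, ethyl and isopropyl on the shared core differ at all in this assay.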